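Swapping a urea chain for phenyl on the sulfonyl

The source may hold more compounds than are shown below. What is called first, only, known or untested is meant among the compounds shown, and "the series" means these compounds.

Three compounds share one core and differ only in the group on the sulfonyl sulfur. Compound 1 `O=C(NS(=O)(=O)c1ccc(F)cc1)c1ccc(Nc2nc(NC3(c4ccc(Cl)cc4)CC3)nc(OCC(F)(F)F)n2)cc1` carries a 4-fluorophenyl there and, in an ADME assay on microsomes from liver (Homo sapiens) for metabolic stability, with a stated time of 10 min (on this read-out lower numbers stand for a less stable compound and higher numbers for a more stable compound), compound 1 gives 100%. Compound 2 `CC(C)NCCS(=O)(=O)NC(=O)c1ccc(Nc2nc(NC3(c4ccc(Cl)cc4)CC3)nc(OCC(F)(F)F)n2)cc1` carries a 2-(isopropylamino)ethyl chain instead; in this assay compound 2 gives 89%, and the step of a number 11 percentage points lower from compound 1 to compound 2 (beyond the scatter). Compound 3 `CC(C)(C)NC(=O)NCCS(=O)(=O)NC(=O)c1ccc(Nc2nc(NC3(c4ccc(Cl)cc4)CC3)nc(OCC(F)(F)F)n2)cc1` carries a 2-(((tert-butyl)carbamoyl)amino)ethyl chain; in this assay compound 3 gives 96%, which is the second highest of the three numbers, with a number 4 percentage points lower from compound 1 to compound 3 (within the scatter) and a number 7 percentage points higher from compound 2 to compound 3 (within the scatter).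

Compound 4 `O=C(NS(=O)(=O)c1ccccc1)c1ccc(Nc2nc(NC3(c4ccc(Cl)cc4)CC3)nc(OCC(F)(F)F)n2)cc1` is not yet measured. The change is phenyl in place of 2-(((tert-butyl)carbamoyl)amino)ethyl on a sulfonyl sulfur. The nearest measured guide is the step from compound 1 to compound 3, which went the other way and stayed within the scatter, so the reverse direction toward an aromatic ring is expected to change little. Compound 4 is therefore estimated to give 97%, within a range from 87% to 100%, a step of a number 1 percentage points higher from compound 3 to compound 4 (within the scatter) that is not expected to pass beyond the scatter.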

Compound 4, percent of the compound remaining: 100%
For compound 4 the middle estimate is 3 percentage points below the measured one, and the stated range covers the measured number.
By their numbers in this assay, from the lowest: compounds 2, 3, 1 and 4 (each within the scatter of the next, the first and the last beyond it).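

In this assay the unsubstituted phenyl on the sulfonyl sulfur gives a number 11 percentage points higher from compound 2 to compound 4 (beyond the scatter) and a number 4 percentage points higher from compound 3 to compound 4 (within the scatter), so an aromatic ring separates clearly only from the amine chain, not from the urea chain. Taking the fluoro off the aromatic carbon gives no change at the digits printed from compound 1 to compound 4 (within the scatter), which shows that the ring needs no fluoro to reach this reading; compound 3 stays the exception to any simple split between rings and chains. No measurement is at hand that would account for these numbers.

Still open, going by these compounds, is how a carboxylic acid at the end of the ethyl chain, a longer chain or a small methyl group on the sulfonyl sulfur would read. Equally open, on these data alone, is whether a pyridine ring or a methoxy group on the phenyl would keep the reading of compound 4.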